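The source may report more compounds than this note shows. Statements on the series, on what has been measured and on what is new or still open speak of the compounds shown alone.

For the measured compounds named here, compound 1, with the structure `Cc1cccc(CN(C)C(=O)c2cc(Cl)c(O)cc2O)c1`, has the highest of the three numbers measured so far in a functional assay on SK-BR-3 cells (Homo sapiens) for antiproliferative activity, with a stated time of 72 h (on this read-out higher numbers stand for weaker inhibition of growth and lower numbers for stronger inhibition of growth), where compound 1 gives 11300 nM. The two companions sit close by: compound 2, with the structure `COc1cc(CN(C)C(=O)c2cc(Cl)c(O)cc2O)c(Br)c(OC)c1OC`, gives 7700 nM in this assay, and compound 3, with the structure `COc1ccc(CN(C)C(=O)c2cc(Cl)c(O)cc2O)cc1`, gives 7200 nM. Both of those numbers lie within the scatter of the reading for compound 1, so the three compounds cannot be told apart with confidence, and none of them can be called stronger or weaker than another. All three share the same core, a chlorinated dihydroxybenzamide, and differ only in the aromatic group carried on the saturated chain carbon bound to the amide-type nitrogen.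

Compound 4, with the structure `Cc1ccccc1CN(C)C(=O)c1cc(Cl)c(O)cc1O`, has not yet been measured. It differs from compound 1 in one place: 2-methylphenyl in place of 3-methylphenyl on a saturated chain carbon bound to an amide-type nitrogen. The same atoms are present, joined differently. Going by the values given here, no measured pair among the three compounds shows a change of this kind, so there is no direct guide to its effect. Since the variations seen so far across the aromatic group all stayed within the scatter, the step from compound 1 to compound 4 is expected to be small, a 1.1-fold lower number from compound 1 to compound 4 (0.05 log units; within the scatter), with no clear direction. Compound 4 is therefore estimated to give about 10000 nM in this assay, with a likely range from 4000 nM to 25000 nM.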

Compound 4, concentration for 50% growth inhibition: 4200 nM
The estimate for compound 4 lay 2.4-fold (0.38 log units) above the measured number; low and high end bracket the measured number.
By their numbers in this assay, from the lowest: compounds 4, 3, 2 and 1 (each within the scatter of the next, the first and the last beyond it).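

For the compounds shown here, replacing 3-methylphenyl with 2-methylphenyl on a saturated chain carbon bound to an amide-type nitrogen gives a 2.7-fold lower number from compound 1 to compound 4 (0.43 log units; beyond the scatter) in this assay and is the first step in this set that can be read as a real difference, although a modest one. Going by these compounds alone, the two groups have the same atoms and the same counted features, so the way those atoms are joined is the only change, and this alone is enough to shift the read-out beyond the scatter. The aromatic group at this place is therefore not indifferent to its arrangement, but nothing shown here explains why this change lowers the number.

The compounds shown leave open whether the methyl group itself matters, which a plain phenyl group or 4-methylphenyl at the same place could help to settle. They also leave open whether the lower number belongs to methyl alone or would also appear with another group in the same arrangement, such as 2-chlorophenyl, 2-methoxyphenyl, 2-ethylphenyl or a phenyl ring carrying an amine or a carboxylic acid.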